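Cyclopropyl Exchanged for Isopropyl on a Shared Core

This account rests on a few compounds, and the source may have more. Where it says the series, first, only, none or still open, it means among the compounds named here.

Three amides on one shared core make up this set. In an ADME assay on microsomes from liver (Homo sapiens) for metabolic stability, with a stated time of 30 min (a lower number here means that less of the compound is left, a higher number that more of the compound is left), compound 1 `CC(C)(O)C(=O)N[C@@H](CO)C(=O)O` gives "not determined" (no result reported). For the measured compounds named here, compound 2 `O=C(N[C@@H](CO)C(=O)O)C1CC1` is thus the only compound with a number: in this assay compound 2 gives 26%. Compound 3 `CC(C)C(=O)N[C@@H](CO)C(=O)O` differs from compound 2 in one place: isopropyl in place of cyclopropyl on a carbonyl carbon. Going by the values given here, no step between measured compounds exists to guide this change, so the expected shift is small, a slight fall that need not clear the scatter: a number 6 percentage points lower from compound 2 to compound 3 (within the scatter). For compound 3 in this assay the estimate is 20%, within a range from 6% to 42%.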

Compound 3, percent of the compound remaining: 84%
Estimate against measurement, compound 3: 64 percentage points below; measured number outside the range, above it.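

In this assay, the position on a carbonyl carbon turns out to respond strongly to this exchange: isopropyl in place of cyclopropyl gives a number 58 percentage points higher from compound 2 to compound 3 (beyond the scatter). The two groups have the same count of heavy atoms, all carbon, and differ in that cyclopropyl carries a ring and isopropyl does not, so a change of this kind at this position is not a minor one here. Nothing at hand accounts for the size of this step. Steps to compound 1 cannot be read, as it has no number. As far as these compounds go, whether a cyclobutyl or tert-butyl group on the same carbonyl carbon would follow isopropyl or cyclopropyl remains open.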